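Fluoro for chloro on the sulfonamide-bearing ring

This account rests on a few compounds, and the source may have more. Where it says the series, first, only, none or still open, it means among the compounds named here.

Compound 2 `CS(=O)(=O)Nc1ccc(NC(=O)c2cc(C(F)(F)F)cc(C(F)(F)F)c2)cc1Cl` in an ADME assay on RAW264.7 cells (Mus musculus) for cytotoxicity, read by MTT assay, with a stated time of 48 h (a lower number here means a stronger inhibitor, a higher number a weaker inhibitor), gives 69600 nM, the highest of the two numbers shown. Its nearest neighbour is compound 3 `CCS(=O)(=O)Nc1ccc(NC(=O)c2cc(C(F)(F)F)cc(C(F)(F)F)c2)cc1Cl`, which in this assay gives 64100 nM; the step of a 1.1-fold lower number from compound 2 to compound 3 (0.04 log units; within the scatter) lies within the scatter. Compound 1 `COc1cc(NC(=O)c2cc(C(F)(F)F)cc(C(F)(F)F)c2)ccc1NS(C)(=O)=O` in this assay reports only a limit, > 250000 nM. That is the limit of > 250000 nM in this assay, at which 1 of the 3 values shown sits. The step of an at least 3.5-fold lower number from compound 1 to compound 2 (0.55 log units; beyond the scatter) is beyond the scatter.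

Compound 4 `CS(=O)(=O)Nc1ccc(NC(=O)c2cc(C(F)(F)F)cc(C(F)(F)F)c2)cc1F` differs from compound 2 by fluoro in place of chloro on an aromatic carbon. Of the measured steps only an at least 3.5-fold lower number from compound 1 to compound 2 (0.55 log units; beyond the scatter) touches the same aromatic carbon, and it shows that a change there can move the number by at least a modest amount; the step of a 1.1-fold lower number from compound 2 to compound 3 (0.04 log units; within the scatter) sits elsewhere and does not bear on this exchange. For the measured compounds named here, no measured pair compares two halogens at that carbon, so the direction is not settled. Compound 4 is therefore expected to give 110000 nM in this assay, within 50000 nM to 250000 nM. The expected step of a 1.6-fold higher number from compound 2 to compound 4 (0.20 log units; within the scatter) is modest, toward a higher number.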

Compound 4, half-maximal inhibitory concentration: 125000 nM
The estimate for compound 4 lay 1.1-fold (0.06 log units) below the measured number; the range from low to high includes it.
By their numbers in this assay, from the lowest: compounds 3, 2 and 4 (each within the scatter of the next). At a limit, above all of these: compound 1.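

For the compounds shown here, with this result, two halogens can be compared at the aromatic carbon ortho to a methanesulfonamido group for the first time, and in this assay fluoro in place of chloro gives a 1.8-fold higher number from compound 2 to compound 4 (0.25 log units; within the scatter), so compound 2 and compound 4 cannot be told apart here. Fluoro can also be set against methoxy at this carbon, but the step shows only a floor, an at least 2.0-fold lower number from compound 1 to compound 4 (0.30 log units; that floor lies within the scatter), and so fixes no size for that exchange. Compound 1 reports only a limit: the limit of > 250000 nM in this assay, at which 1 of the 4 values shown sits.

The compounds shown leave open how hydrogen, bromo or an amine on this carbon would compare with chloro and fluoro. They also leave open whether fluoro would give the same picture with a longer chain on the sulfonyl group.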